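The source may hold more compounds than are shown below. What is called first, only, known or untested is meant among the compounds shown, and "the series" means these compounds.

Measured so far:
compound 1 `COc1ccc(C2=C(c3cc(OC)c(OC)c(OC)c3)C(=O)CC2O[SiH2]C(C)(C)C)cc1` — > 100 ug/mL
compound 2 `COc1ccc(OC)c(C2=C(c3cc(OC)c(OC)c(OC)c3)C(=O)CC2O[SiH2]C(C)(C)C)c1` — 10 ug/mL
compound 3 `COc1ccc(C2=C(c3cc(OC)c(OC)c(OC)c3)C(=O)C(O)C2)cc1NC(=O)c1ccccc1` — > 100 ug/mL

Among the compounds with values here, in an ADME assay on KB cells (Homo sapiens) for cytotoxicity, read by MTT assay, with a stated time of 72 h (on this read-out lower numbers stand for stronger inhibition and higher numbers for weaker inhibition), compound 2 gives 10 ug/mL, the only actual number among the three. Compound 1 sits at a limit, > 100 ug/mL. Compound 3 likewise sits at a limit, > 100 ug/mL. Within the data shown here, the one step that can be sized is an at least 10-fold lower number from compound 1 to compound 2 (1.00 log units; beyond the scatter), and it is the only measured change at the double-bonded ring carbon that compound 4 also alters.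

Compound 4 `COC(=O)c1cc(C2=C(c3cc(OC)c(OC)c(OC)c3)C(=O)CC2O[SiH2]C(C)(C)C)ccc1OC` differs from compound 2 in one place: 4-methoxy-3-(methoxycarbonyl)phenyl in place of 2,5-dimethoxyphenyl on a double-bonded ring carbon. Among the measured compounds shown here, the 4-methoxy arrangement that enters here is the one that compound 1 carried, where only a limit was recorded, so the single step that bears on this position points toward a weaker compound rather than a stronger one; the methoxycarbonyl adds a group for which no step exists. Because two of the three values sit at the limit of > 100 ug/mL in this assay, at which 2 of the 3 values shown sit, a limit is a real possibility for compound 4 as well.

The step expected is a 4.0-fold higher number from compound 2 to compound 4 (0.60 log units; beyond the scatter), toward a higher number. The estimate for compound 4 is 40 ug/mL, with a range from 10 ug/mL to 150 ug/mL.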

Compound 4, half-maximal inhibitory concentration: > 100 ug/mL
Compound 4: only a limit was reported; the forecaster's own chance of this, stated with the estimate: 45%; at least 2.5-fold (0.39 log units) between middle value and limit.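

In this assay, the change on the double-bonded ring carbon to 4-methoxy-3-(methoxycarbonyl)phenyl in place of 2,5-dimethoxyphenyl gives an at least 10-fold higher number from compound 2 to compound 4 (1.00 log units; beyond the scatter), so a second replacement of the 2,5-dimethoxyphenyl group now also ends at a limit. Among compound 1, compound 2 and compound 4, which differ only in the aryl group at this position, compound 2 alone gives an actual number, and the position therefore tolerates neither of the two other substitution patterns shown without loss of that number. The step for methoxycarbonyl in place of hydrogen on an aromatic carbon, which links the two limit compounds, cannot be read, so no separate contribution of the methoxycarbonyl can be drawn from the data.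

Still open, as far as these compounds go, is whether both methoxy groups of the 2,5-dimethoxyphenyl are needed, and whether a carboxylic acid or an amine in place of the methoxycarbonyl would give a measurable number. Any ranking among the weaker compounds in this assay remains out of reach: the limit of > 100 ug/mL in this assay, at which 3 of the 4 values shown sit.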